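Aryl variation on the aromatic amine of a hydroxamate series

The source may report more compounds than this note shows. Statements on the series, on what has been measured and on what is new or still open speak of the compounds shown alone.

Measured so far:
compound 1 `O=C(CCCCCCC(=O)Nc1cc2ncnc(Nc3ccc(Cl)cc3F)c2s1)NO` — 37 nM
compound 2 `CCc1cccc(Nc2ncnc3cc(NC(=O)CCCCCCC(=O)NO)sc23)c1` — 58.5 nM

In an assay on cells for inhibition of protein deacetylase HDAC6 (Homo sapiens), with a stated time of 3 h (on this read-out lower numbers stand for stronger inhibition and higher numbers for weaker inhibition), compound 1 gives 37 nM, the lower of the two numbers shown, while compound 2 gives 58.5 nM; the step of a 1.6-fold higher number from compound 1 to compound 2 (0.20 log units; within the scatter) sits inside the scatter, so no order between them is claimed. Compound 3 `CCc1ccc(Nc2ncnc3cc(NC(=O)CCCCCCC(=O)NO)sc23)cc1` differs from compound 1 in one place: 4-ethylphenyl in place of 4-chloro-2-fluorophenyl on a nitrogen on an aromatic ring. For the measured compounds named here, the only measured step that bears on this change is the one of compound 2, which was small. Compound 3 is therefore expected to show no step beyond the scatter, a 1.4-fold higher number from compound 1 to compound 3 (0.13 log units; within the scatter). The estimate for compound 3 is 50 nM, with a range from 20 nM to 130 nM.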

Compound 3, half-maximal inhibitory concentration: 98.3 nM
The estimate for compound 3 lay 2.0-fold (0.29 log units) below the measured number; low and high end bracket the measured number.
By their numbers in this assay, from the lowest: compounds 1, 2 and 3 (each within the scatter of the next, the first and the last beyond it).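

In this assay, for the compounds shown here, this position proves not wholly indifferent to the aryl group: 4-ethylphenyl in place of 4-chloro-2-fluorophenyl gives a 2.7-fold higher number from compound 1 to compound 3 (0.42 log units; beyond the scatter) as the first step beyond the scatter, a modest one. Shifting the ethyl group, with 4-ethylphenyl in place of 3-ethylphenyl, gives a 1.7-fold higher number from compound 2 to compound 3 (0.23 log units; within the scatter) and so does not separate the two ethylphenyl compounds. No measured evidence bears on either step.

Open, as far as these compounds go, is whether the chlorine or the fluorine of compound 1 matters more here, and how a 4-chlorophenyl or 4-aminophenyl group would read on this nitrogen.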